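Swapping Chloro for Fluoro: Expected Effect on Solubility

The source may report more compounds than this note shows. Statements on the series, on what has been measured and on what is new or still open speak of the compounds shown alone.

Of the compounds shown here, three have been measured in a physicochemical assay for solubility, in phosphate buffer, at pH 6.5; on this read-out higher numbers stand for higher solubility and lower numbers for lower solubility. Compound 1 `CCOc1cc(CN2CCC(NC(=O)c3ccc(NC(C)C)nc3)CC2)cc(OCC)c1F` gives only a limit of the assay, > 520 ug/mL. Compound 2 `CCOc1cc(CN2CCC(NC(=O)c3cncc(C)c3)CC2)ccc1C` likewise reaches a limit rather than a number, > 433 ug/mL. Compound 3 `CCOc1cc(CN2CCC(NC(=O)c3cncc(C)c3)CC2)cc(OCC)c1Cl` is the only one of the three with a true number, giving 216 ug/mL in this assay, and so stands as the single fixed point. Compound 4 `CCOc1cc(CN2CCC(NC(=O)c3cncc(C)c3)CC2)cc(OCC)c1F` differs from compound 3 by fluoro in place of chloro on an aromatic carbon. Among the compounds with values here, no measured pair differs in just one place, so no step in this assay is available for direct comparison. On the measured values alone, a modest upward step is expected, a 1.6-fold higher number from compound 3 to compound 4 (0.20 log units; within the scatter). Compound 4 is therefore estimated at 340 ug/mL, with a range from 170 ug/mL to 520 ug/mL.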

Compound 4, solubility: 443 ug/mL
Compound 4: the middle estimate sits 1.3-fold (0.11 log units) below what was measured; the range from low to high includes it.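

Within the data shown here, on the aromatic carbon ortho to two ethoxy groups and para to a large group, fluoro in place of chloro gives the first single-change step in this assay: a 2.1-fold higher number from compound 3 to compound 4 (0.31 log units; beyond the scatter). Compound 1 gives only a limit, > 520 ug/mL. The change of 6-(isopropylamino)pyridin-3-yl to 5-methylpyridin-3-yl therefore yields only a floor: an at least 1.1-fold lower number from compound 1 to compound 4 (0.06 log units; that floor lies within the scatter).

Nothing shown accounts for the halogen step. On these data alone, whether a methoxy or a nitrile at this position would give a higher or lower number remains open.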